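The source may report more compounds than this note shows. Statements on the series, on what has been measured and on what is new or still open speak of the compounds shown alone.

In an assay for binding affinity to dual specificity mitogen-activated protein kinase kinase 4 (Homo sapiens), read by KINOMEscan, tested at 100 nM (a lower number here means a stronger effect, a higher number a weaker effect of the compound at the concentration tested), the measured compounds are:
compound 1 `CCCS(=O)(=O)Nc1ccc(F)c(C(=O)c2n[nH]c3ncc(-c4ccccc4OC)cc23)c1F`, which gives 1.9%;
compound 2 `CCCS(=O)(=O)Nc1ccc(F)c(C(=O)c2n[nH]c3ncc(-c4ccc(Cl)c(C(F)(F)F)c4)cc23)c1F`, which gives 15%;
compound 3 `CCCS(=O)(=O)Nc1ccc(F)c(C(=O)c2n[nH]c3ncc(-c4ccc(C(F)(F)F)cc4)cc23)c1F`, which gives 29%.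

Compound 3 stands at the highest number of the three: a number 27.1 percentage points higher from compound 1 to compound 3 (beyond the scatter) and a number 14 percentage points higher from compound 2 to compound 3 (beyond the scatter). Compound 4 `CCCS(=O)(=O)Nc1ccc(F)c(C(=O)c2n[nH]c3ncc(-c4ccc(S(N)(=O)=O)cc4)cc23)c1F` differs from compound 3 by sulfamoyl in place of trifluoromethyl on an aromatic carbon. Going by the values given here, no measured step exchanges trifluoromethyl for sulfamoyl, so the known steps bear on this one only loosely; they show that changing a group on this ring shifts this assay by modest amounts, as in a number 13.1 percentage points higher from compound 1 to compound 2 (beyond the scatter). The step to compound 4 is therefore expected to be a number 14 percentage points lower from compound 3 to compound 4 (beyond the scatter), with wide uncertainty in either direction. For compound 4 the estimate is 15%, within a range from 2% to 55%.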

Compound 4, a percentage reported as activity, at one concentration (the size of the read-out at that concentration, not a potency): 0.25%
For compound 4 the middle estimate is 14.8 percentage points above the measured one, outside the stated range (below it).
By their numbers in this assay, from the lowest: compounds 4 and 1 (each within the scatter of the next); then compound 2; then compound 3.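

In this assay, sulfamoyl in place of trifluoromethyl on this ring, para to a large group, gives a number 28.8 percentage points lower from compound 3 to compound 4 (beyond the scatter) and thus shows that the group at this place can shift the read-out more than the earlier para-substituted rings suggested. The 4-sulfamoylphenyl group also gives a number 14.8 percentage points lower from compound 2 to compound 4 (beyond the scatter) and a number 1.7 percentage points lower from compound 1 to compound 4 (within the scatter), so it cannot be told apart here from the 2-methoxyphenyl group. Nothing available explains these shifts. On these data alone, whether a methylsulfonyl group, a carboxylic acid or an amine at this place would match sulfamoyl remains open. So does the effect of moving sulfamoyl elsewhere on this ring.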